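Carbonyl group exchange from compound 3 to compound 4

This account rests on a few compounds, and the source may have more. Where it says the series, first, only, none or still open, it means among the compounds named here.

In an ADME assay on Caco-2 cells (Homo sapiens) for permeability, in the apical to basolateral direction, with a stated time of 90 min, tested at 10 uM (on this read-out higher numbers stand for higher permeability and lower numbers for lower permeability), compound 1 (`O=C(NC[C@@H]1[C@H]2CN(C(=O)OCc3cc(Cl)cc(Cl)c3)C[C@@H]12)c1ccc2[nH]c(=O)oc2c1`) gives 137 10^-6 cm/s, compound 2 (`O=C(NC[C@@H]1[C@H]2CN(C(=O)/C=C/c3cc(Cl)cc(Cl)c3)C[C@@H]12)c1ccc2[nH]c(=O)oc2c1`) gives 38 10^-6 cm/s and compound 3 (`O=C(NC[C@@H]1[C@H]2CN(C(=O)C3CC3c3cc(Cl)cc(Cl)c3)C[C@@H]12)c1ccc2[nH]c(=O)oc2c1`) gives 64 10^-6 cm/s. Compound 3 stands with compound 2, as a 1.7-fold higher number from compound 2 to compound 3 (0.23 log units; within the scatter) shows, and under compound 1, as a 2.1-fold lower number from compound 1 to compound 3 (0.33 log units; beyond the scatter) shows. Compound 4 (`O=C(NC[C@@H]1[C@H]2CN(C(=O)NCc3cc(Cl)cc(Cl)c3)C[C@@H]12)c1ccc2[nH]c(=O)oc2c1`) carries a group of 10 heavy atoms (7 carbon, 1 nitrogen, 2 chlorine; one six-membered aromatic ring of carbon only) in place of a group of 11 heavy atoms (9 carbon, 2 chlorine; one three-membered non-aromatic ring of carbon only, one six-membered aromatic ring of carbon only), on a carbonyl carbon; the entering (3,5-dichlorobenzyl)amino has 1 hydrogen-bond donor, the leaving group 0 hydrogen-bond donors. The nearest guide is a 3.6-fold lower number from compound 1 to compound 2 (0.56 log units; beyond the scatter), modest like the step to compound 3 from compound 1, and none of these steps tests the entering group. The expected change is small and downward, a 1.6-fold lower number from compound 3 to compound 4 (0.20 log units; within the scatter), probably not beyond the scatter. For compound 4 the estimated value is 40 10^-6 cm/s, with an expected range of 15 10^-6 cm/s to 100 10^-6 cm/s.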

Compound 4, apparent permeability: 2 10^-6 cm/s
The estimate for compound 4 lay 20-fold (1.30 log units) above the measured number, outside the stated range (below it).
By their numbers in this assay, from the lowest: compound 4; then compounds 2 and 3 (each within the scatter of the next); then compound 1.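

At this carbonyl carbon, (3,5-dichlorobenzyl)amino, with 1 hydrogen-bond donor, sits far under every earlier group in this assay: a 32-fold lower number from compound 3 to compound 4 (1.51 log units; beyond the scatter), a 19-fold lower number from compound 2 to compound 4 (1.28 log units; beyond the scatter) and a 69-fold lower number from compound 1 to compound 4 (1.84 log units; beyond the scatter). The last step keeps the 3,5-dichlorobenzyl part and exchanges only oxygen for nitrogen, so the position that had tolerated modest steps turns out to be sharply sensitive to this one linking atom. Nothing available explains this loss. On these data alone, whether a methyl group on that nitrogen, or a longer chain before the aromatic ring, would restore the number remains open.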